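Replacing 2-fluorophenyl in compound 2 with pyrimidin-2-yl

A few compounds are considered here, and "the series" means these few. Any claim that something is new, unique, unknown or untested is made for them only; others in the source may bear on it.

Compound 1 `Nc1nc(N)c2cc(CSC(=S)N3CCN(c4ccccc4)CC3)ccc2n1`: 2970 nM
Compound 2 `Nc1nc(N)c2cc(CSC(=S)N3CCN(c4ccccc4F)CC3)ccc2n1`: 6460 nM

In a functional assay on A549 cells (Homo sapiens) for antiproliferative activity, read by MTT assay, with a stated time of 72 h (on this read-out lower numbers stand for stronger inhibition and higher numbers for weaker inhibition), compound 2 gives the higher of the two numbers, at 6460 nM, and is the weaker of the pair. Going by the values given here, the one measured step is a 2.2-fold higher number from compound 1 to compound 2 (0.34 log units; beyond the scatter), a modest change from fluoro in place of hydrogen on an aromatic carbon. Compound 3 `Nc1nc(N)c2cc(CSC(=S)N3CCN(c4ncccn4)CC3)ccc2n1` carries pyrimidin-2-yl in place of 2-fluorophenyl on an amine nitrogen in a ring. The measured step bears only loosely on this change, as neither measured compound has an aromatic ring with hetero atoms at this place. A step of similarly modest size is therefore expected, leaning weakly towards a lower number, with the direction uncertain. The expected change is a 1.4-fold lower number from compound 2 to compound 3 (0.16 log units; within the scatter). For compound 3 the estimated value is 4500 nM, with an expected range of 1500 nM to 13000 nM.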

Compound 3, half-maximal inhibitory concentration: 4010 nM
Compound 3: middle estimate off by 1.1-fold (0.05 log units), on the high side; measured number inside the range.
By their numbers in this assay, from the lowest: compounds 1, 3 and 2 (each within the scatter of the next, the first and the last beyond it).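

In this assay, going by these compounds alone, this is the first aromatic ring with hetero atoms on the amine nitrogen in a ring, and the change to pyrimidin-2-yl stays within the scatter against both carbon-only rings (a 1.6-fold lower number from compound 2 to compound 3 (0.21 log units; within the scatter)) and (a 1.4-fold higher number from compound 1 to compound 3 (0.13 log units; within the scatter)). Among these three compounds, only the pair of compound 1 and compound 2 is separated by a step beyond the scatter, so the place tolerates a ring with 2 hydrogen-bond acceptors without a clear shift in either direction. No measurement here offers an explanation for these numbers.

Still open, from the compounds shown here alone, is how pyridin-2-yl, or a non-aromatic group such as methyl or acetyl, would read on the same amine nitrogen. Also open, going by these compounds, is how a chloro or methoxy group on the phenyl ring would compare with fluoro.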